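This account rests on a few compounds, and the source may have more. Where it says the series, first, only, none or still open, it means among the compounds named here.

Measured compounds:
- compound 1, `Oc1cc(/C=C/c2cc(O)c(O)c(O)c2)cc(O)c1O` — 0.9 ug/mL
- compound 2, `O=C(c1cc(O)cc(/C=C/c2ccc(O)cc2)c1)c1cc(O)c(O)c(O)c1` — 16 ug/mL

In a functional assay (on this read-out higher numbers stand for weaker inhibition and lower numbers for stronger inhibition), compound 1 gives 0.9 ug/mL, the lowest of the two numbers recorded so far. Compound 2, `O=C(c1cc(O)cc(/C=C/c2ccc(O)cc2)c1)c1cc(O)c(O)c(O)c1`, gives 16 ug/mL in this assay, a gap from compound 1 that lies well beyond the usual scatter of repeated measurements. Within the data shown here, no single-point step between the two measured compounds is available, so the two values say nothing about any one structural change on their own.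

The next compound, compound 3, `Oc1ccc(/C=C/c2cc(O)c(O)c(O)c2)cc1O`, differs from compound 1 in one place: hydrogen in place of hydroxy on an aromatic carbon. This is a small change that removes one hydroxy from the shared core of compound 1 while leaving the rest of the structure untouched. With no measured step of this kind in the series, the expectation rests on the size of the change alone. A step in this assay from compound 1 to compound 3 is expected to be small, in the direction of a somewhat higher number, and may well stay within the scatter. The estimate for compound 3 is 1.8 ug/mL, with a range from 0.7 ug/mL to 5 ug/mL, which corresponds to an expected step of a 2.0-fold higher number from compound 1 to compound 3 (0.30 log units; within the scatter).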

Compound 3, half-maximal inhibitory concentration: 3 ug/mL
Estimate against measurement, compound 3: 1.7-fold (0.22 log units) below; low and high end bracket the measured number.
By their numbers in this assay, from the lowest: compound 1; then compound 3; then compound 2.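

In this assay the series now has its first step that changes a single place: hydrogen in place of hydroxy on an aromatic carbon gives a 3.3-fold higher number from compound 1 to compound 3 (0.52 log units; beyond the scatter) and so takes the number beyond the scatter. This shows that the hydroxy at this position, ortho to a hydroxy group and meta to a large group, cannot be removed without a modest weakening of inhibition, something the earlier pair, compound 1 and compound 2, could not show for any one position. Nothing at hand bears on the reason for this loss.

The compounds shown leave open whether the other hydroxy groups of the shared core matter to a similar degree, or whether this position is a special case. They also leave open whether a hydroxy is specifically required on this carbon, or whether a methoxy group, a fluorine atom or an amine there would keep the number close to that of compound 1.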